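Swapping the naphthalene arm for a trimethoxyphenyl group

The compounds below may be only part of what the source reports. "The series", "measured", "known", "first", "only" and "open" are said of these compounds alone.

Of the compounds shown here, three sharing one core have been tested in a functional assay on THP-1 cells (Homo sapiens) for inhibition, read by sulforhodamine B assay, tested at 10 uM; a higher number here means more inhibition of growth at the concentration tested, a lower number less inhibition of growth. Compound 1 `COc1cc(C2CC(c3cccc4ccccc34)=NN2C(C)=O)ccc1OCc1cn(Cc2ccc([N+](=O)[O-])cc2)nn1` gives 10%. Compound 2 `COc1cc(C2CC(c3ccc([N+](=O)[O-])cc3)=NN2C(C)=O)ccc1OCc1cn(Cc2ccc([N+](=O)[O-])cc2)nn1` gives 7%, and compound 3 `CC(=O)N1N=C(c2ccc(OCc3cn(Cc4ccc([N+](=O)[O-])cc4)nn3)cc2)CC1c1ccccc1` gives 0%. Compound 1 holds the highest of the three numbers, but its separation from compound 2 and from compound 3 lies within the usual scatter of this measurement, so no real ordering among the three can be read from these values.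

Compound 4 `COc1cc(C2CC(c3cc(OC)c(OC)c(OC)c3)=NN2C(C)=O)ccc1OCc1cn(Cc2ccc([N+](=O)[O-])cc2)nn1` has not yet been measured. It differs from compound 1 in a single place: 3,4,5-trimethoxyphenyl in place of naphthalen-1-yl on a carbon with a double bond to nitrogen

Within the data shown here, one measured step bears on this exchange, since it alters the same position of the core: a number 3 percentage points lower from compound 1 to compound 2 (within the scatter). There the naphthalen-1-yl group gave way to 4-nitrophenyl without any shift beyond the scatter, and all three measured compounds sit at the low end of this assay. On that basis the move to 3,4,5-trimethoxyphenyl is expected to produce no step beyond the scatter, a number 1 percentage points lower from compound 1 to compound 4 (within the scatter). For compound 4 the expected value in this assay is 9%, with a likely range from 0% to 22%.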

Compound 4, percent growth inhibition at one concentration: 29%
For compound 4 the middle estimate is 20 percentage points below the measured one; measured number above the stated range.
By their numbers in this assay, from the lowest: compounds 3, 2 and 1 (each within the scatter of the next); then compound 4.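

At this position, the group clearly matters in this assay: replacing naphthalen-1-yl with 3,4,5-trimethoxyphenyl gives a number 19 percentage points higher from compound 1 to compound 4 (beyond the scatter), and replacing 4-nitrophenyl with it gives a number 22 percentage points higher from compound 2 to compound 4 (beyond the scatter). The earlier step at this position stayed within the scatter and could have suggested that the choice of group here made little difference, but the new steps show that the number can move with this change. No measurement in hand explains why this group stands apart from the other two.

From the compounds shown here alone, it remains open whether all three methoxy groups are needed, or whether a single methoxy group or a dimethylamino group on the phenyl ring would give a similar number. With compound 4 at 29%, how much higher a different group at this position could take the number is also unsettled.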